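A few compounds are considered here, and "the series" means these few. Any claim that something is new, unique, unknown or untested is made for them only; others in the source may bear on it.

Measured compounds:
compound 1, `Cc1cc(Cl)ccc1NC(=O)Nc1nc(Sc2c[nH]c3ccccc23)cc(N2CCN(Cc3ccccc3)CC2)n1`: in a functional assay on MDA-MB-231 cells (Homo sapiens) for inhibition, with a stated time of 72 h (on this read-out higher numbers stand for weaker inhibition and lower numbers for stronger inhibition), compound 1 gives 22100 nM
compound 2, `O=C(Nc1ccc(Cl)cc1)Nc1nc(Sc2c[nH]c3ccccc23)cc(N2CCCCC2)n1`: in this assay compound 2 gives 10100 nM

Compound 1 stands with the higher of the two numbers in this assay; compound 2 sits lower, and the gap between the two goes beyond the usual scatter of repeated measurements. For the measured compounds named here, compound 1 and compound 2 differ from each other in more than one place, so no single step connects them and their two values can only be read side by side.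

Compound 3, `Cc1ccc(C)c(NC(=O)Nc2nc(Sc3c[nH]c4ccccc34)cc(N3CCN(Cc4ccccc4)CC3)n2)c1`, has not yet been measured. It is obtained from compound 1 by the change 2,5-dimethylphenyl in place of 4-chloro-2-methylphenyl on an amide-type nitrogen, the nitrogen whose other neighbour is the carbonyl carbon. Going by the values given here, no measured pair isolates this change, so the step of a 1.1-fold lower number from compound 1 to compound 3 (0.04 log units; within the scatter) expected here rests on no direct precedent; the working expectation is a step that stays within the scatter, with no firm direction. For compound 3 the estimated value in this assay is 20000 nM, with a range from 8000 nM to 50000 nM.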

Compound 3, half-maximal inhibitory concentration: 19000 nM
Estimate against measurement, compound 3: 1.1-fold (0.02 log units) above; the range from low to high includes it.
By their numbers in this assay, from the lowest: compounds 2, 3 and 1 (each within the scatter of the next, the first and the last beyond it).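

In this assay, 2,5-dimethylphenyl in place of 4-chloro-2-methylphenyl on the amide-type nitrogen gives a 1.2-fold lower number from compound 1 to compound 3 (0.07 log units; within the scatter). For the compounds shown here, this is the first single-place comparison, and it shows that at this position the 4-chloro-2-methylphenyl group and the all-carbon 2,5-dimethylphenyl group, which have the same heavy-atom count, cannot be told apart by this read-out, so in this one pair the chlorine is not needed to keep the value within the scatter. No measured property of these compounds bears on this result, and the pair itself gives no account of it.

The compounds shown leave open whether this position responds at all to a group of a different kind, such as a phenyl ring carrying a carboxylic acid or a dimethylamino group, or a longer chain such as hexyl in place of the aromatic ring. Compound 2 differs from compound 1 and from compound 3 in more than one place, so the contribution of the other substituent on the shared core remains unseparated from that of the group on the amide-type nitrogen.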